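The compounds below may be only part of what the source reports. "The series", "measured", "known", "first", "only" and "open" are said of these compounds alone.

Values measured so far in an ADME assay on CCRF-CEM cells (Homo sapiens) for antiproliferative activity, with a stated time of 48 h; a lower number here means a stronger inhibitor, a higher number a weaker inhibitor

Compound 1 `C=C(Br)C(=O)Nc1ccc(/C=C/C(=O)c2ccc(Cl)c(Cl)c2)cc1` gives 1700 nM
Compound 2 `C=C(Br)C(=O)Nc1ccc(/C=C/C(=O)c2cc(OC)c(OC)c(OC)c2)cc1` gives 1100 nM
Compound 3 `C=C(Br)C(=O)Nc1ccc(/C=C/C(=O)c2cccc3ccccc23)cc1` gives 3100 nM

These three compounds share one core and differ only in the group on a carbonyl carbon. Compound 1 at 1700 nM sits within the usual scatter of both compound 2 and compound 3, so it cannot be ranked against either of them.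

The next compound to consider is compound 4 `C=C(Br)C(=O)Nc1ccc(/C=C/C(=O)c2cccs2)cc1`, which keeps the core of compound 1 and changes one thing: thiophen-2-yl in place of 3,4-dichlorophenyl on a carbonyl carbon. Among the measured compounds shown here, no measured pair offers a direct guide to this swap. The only help comes from the values themselves. Quite different groups at that spot still leave compound 2 at 1100 nM and compound 3 at 3100 nM, which is a modest span. For the measured compounds named here, the incoming five-membered aromatic ring with 1 hetero atom has no counterpart among the measured compounds, so the range has to stay wide and no direction can be argued. The expected step of a 1.1-fold higher number from compound 1 to compound 4 (0.02 log units; within the scatter) is therefore none beyond the scatter. For compound 4 the estimated value is 1800 nM with an expected range of 700 nM to 4500 nM in this measurement.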

Compound 4, half-maximal inhibitory concentration: 730 nM
Compound 4: the middle estimate sits 2.5-fold (0.39 log units) above what was measured; the range from low to high includes it.
By their numbers in this assay, from the lowest: compounds 4, 2, 1 and 3 (each within the scatter of the next, the first and the last beyond it).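

In this assay, among the compounds shown here, putting thiophen-2-yl in place of 3,4-dichlorophenyl on a carbonyl carbon gives a 2.3-fold lower number from compound 1 to compound 4 (0.37 log units; beyond the scatter) and is the first step at this position that rises beyond the scatter, although only modestly. The three earlier compounds could not be separated from one another in this way, whereas compound 4 at 730 nM and compound 3 at 3100 nM now mark two ends that lie beyond the scatter of each other, with compound 2 at 1100 nM still within the scatter of compound 4. The swap alters several things at once, replacing a six-membered aromatic ring of carbon only, with 8 heavy atoms, by a five-membered aromatic ring with 1 hetero atom, with 5 heavy atoms and 1 hydrogen-bond acceptor, and nothing available here says which of these differences accounts for the step.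

On these data alone, how furan-2-yl, with oxygen as its ring hetero atom, or an unsubstituted phenyl would read at this place remains open. Without such neighbours, the compounds shown cannot separate a role for the sulfur-containing ring from a role for the loss of the two chlorine atoms.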